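A few compounds are considered here, and "the series" means these few. Any claim that something is new, unique, unknown or untested is made for them only; others in the source may bear on it.

Of the compounds shown here, three have been tested in a functional assay on HeLa cells (Homo sapiens) for antiproliferative activity, read by sulforhodamine B assay, with a stated time of 72 h; on this read-out lower numbers stand for stronger inhibition and higher numbers for weaker inhibition.
Compound 1 `S=C(N/N=C/c1ccc2ccccc2n1)Nc1ccc(Br)cc1` gives 56800 nM.
Compound 2 `Fc1cccc(NC(=S)N/N=C/c2ccc3ccccc3n2)c1` gives 70100 nM.
Compound 3 `Cc1ccccc1NC(=S)N/N=C/c1ccc2ccccc2n1` returns only > 100000 nM, which is a limit of the assay and not a number.

Compound 3 thus stands at the limit of > 100000 nM in this assay, at which 1 of the 3 values shown sits, with no value of its own to compare. Compound 4 `FC(F)(F)c1ccccc1NC(=S)N/N=C/c1ccc2ccccc2n1` differs from it by trifluoromethyl in place of methyl on an aromatic carbon. The measured steps that touch compound 3, an at least 1.7-fold higher number from compound 1 to compound 3 (0.24 log units; that floor lies within the scatter) and an at least 1.4-fold higher number from compound 2 to compound 3 (0.15 log units; that floor lies within the scatter), each swap the whole aryl group on the amide-type nitrogen and run into this same limit; none exchanges one group for another on the ring itself. All three compounds fall within the scatter of one another, so no step beyond the scatter is expected here. Compound 4 is therefore expected near 120000 nM, within 50000 nM to 300000 nM, an expected step that the limit leaves unreadable from compound 3 to compound 4.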

Compound 4, half-maximal inhibitory concentration: 18800 nM
Estimate against measurement, compound 4: 6.4-fold (0.81 log units) above, and the stated range ends above it.
By their numbers in this assay, from the lowest: compound 4; then compounds 1 and 2 (each within the scatter of the next). At a limit, above all of these: compound 3.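

Trifluoromethyl in place of methyl on this aromatic carbon, ortho to a large group, gives an at least 5.3-fold lower number from compound 3 to compound 4 (0.72 log units; beyond the scatter) in this assay and so the first step beyond the scatter among these compounds. Going by these compounds alone, it is also the only step here that exchanges a group on the ring itself, while the earlier steps swap the whole aryl group and have floors within the scatter. Compound 3 stands at a limit and not a number, so the full size of this step stays unread: the limit of > 100000 nM in this assay, at which 1 of the 4 values shown sits.

On these data alone, whether a chlorine atom, a methoxy group or an amine on this same carbon would also lower the number remains open. So does whether trifluoromethyl elsewhere on the ring would give a comparable step.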